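Oxime to ketone on an allyl-bearing triazole core

This account rests on a few compounds, and the source may have more. Where it says the series, first, only, none or still open, it means among the compounds named here.

In a functional assay on the whole organism (strain albino) for inhibition, with Rattus norvegicus as the target, read by paw edema, with a stated time of 2 h, at a dose of 0.28 mmol/kg by the oral route (on this read-out lower numbers stand for less inhibition and higher numbers for more inhibition at the one dose given (going by the name of the read-out)), compound 1 `CCn1c(SCC(=O)c2ccccc2)nnc1-c1cc(OC)c(OC)c(OC)c1` gives 41%, compound 2 `CCn1c(SC/C(=N/O)c2ccccc2)nnc1-c1cc(OC)c(OC)c(OC)c1` gives 67%, and compound 3 `C=CCn1c(SC/C(=N/O)c2ccccc2)nnc1-c1cc(OC)c(OC)c(OC)c1` gives 68%. The change from compound 2 to compound 1, (a group of 8 heavy atoms (7 carbon, 1 oxygen; one six-membered aromatic ring of carbon only) in place of a group of 9 heavy atoms (7 carbon, 1 nitrogen, 1 oxygen; one six-membered aromatic ring of carbon only), on a saturated chain carbon bound to a sulfur), made a step of a number 26 percentage points lower from compound 2 to compound 1 (beyond the scatter). The cores of compound 2 and compound 3 differ by vinyl in place of methyl on a saturated chain carbon bound to an aromatic nitrogen, with a step of a number 1 percentage points higher from compound 2 to compound 3 (within the scatter). Compound 4 `C=CCn1c(SCC(=O)c2ccccc2)nnc1-c1cc(OC)c(OC)c(OC)c1` is not yet measured; it differs from compound 3 by a group of 8 heavy atoms (7 carbon, 1 oxygen; one six-membered aromatic ring of carbon only) in place of a group of 9 heavy atoms (7 carbon, 1 nitrogen, 1 oxygen; one six-membered aromatic ring of carbon only), on a saturated chain carbon bound to a sulfur, the same change seen between compound 2 and compound 1, at the same place. The step from compound 3 to compound 4 in this assay is therefore expected to be a number 26 percentage points lower from compound 3 to compound 4 (beyond the scatter), resting on the value of compound 3, 68%, and on the earlier step of a number 26 percentage points lower from compound 2 to compound 1 (beyond the scatter). Compound 4 is estimated at 42%, between 30% and 55%.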

Compound 4, a percentage reported as inhibition, in the whole organism at one dose (the size of the read-out at that dose, not a potency): 62%
The estimate for compound 4 lay 20 percentage points below the measured number; the measured number lies above the stated range.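

In this assay, the change to benzoyl on a saturated chain carbon bound to a sulfur gives a number 6 percentage points lower from compound 3 to compound 4 (within the scatter), so its size does not carry over from the core of compound 2 to the core of compound 3: the same change on two cores in this assay, a number 26 percentage points lower (beyond the scatter) from compound 2 to compound 1 and a number 6 percentage points lower (within the scatter) from compound 3 to compound 4, 20 percentage points apart, beyond the scatter of two such steps. Read the other way, vinyl in place of methyl on a saturated chain carbon bound to an aromatic nitrogen gives a number 21 percentage points higher from compound 1 to compound 4 (beyond the scatter), so that change too depends on the group it is paired with: the same change on two cores in this assay, a number 1 percentage points higher (within the scatter) from compound 2 to compound 3 and a number 21 percentage points higher (beyond the scatter) from compound 1 to compound 4, 20 percentage points apart, beyond the scatter of two such steps. The two changes therefore do not act independently in these four compounds, but this does not show why, and one such set says nothing about other cores.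

The compounds shown leave open how a longer chain on the aromatic nitrogen would behave. They also leave open whether an amine or a carboxylic acid in place of the benzoyl group would follow either pattern.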